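This account rests on a few compounds, and the source may have more. Where it says the series, first, only, none or still open, it means among the compounds named here.

In a toxicity assay on MT4 cells (Homo sapiens) for cytotoxicity, read by MTT assay, with a stated time of 5 days (on this read-out higher numbers stand for lower toxicity in this test and lower numbers for higher toxicity in this test), compound 1 (`Cc1cc(-c2ccco2)cc(C)c1Nc1ccnc(Nc2ccc(C#N)cc2)n1`) gives 1700 nM, compound 2 (`Cc1cc(-c2cc3ccccc3s2)cc(C)c1Nc1ccnc(Nc2ccc(C#N)cc2)n1`) gives 138000 nM, and compound 3 (`Cc1ccc(-c2cc(C)c(Nc3ccnc(Nc4ccc(C#N)cc4)n3)c(C)c2)s1`) gives 28000 nM, the middle of the three numbers. Compound 4 (`Cc1cc(-c2ccnc(C(F)(F)F)c2)cc(C)c1Nc1ccnc(Nc2ccc(C#N)cc2)n1`) has not yet been measured. It carries 2-(trifluoromethyl)pyridin-4-yl in place of 5-methylthiophen-2-yl on an aromatic carbon. Three swaps at the same place bear on this change: an 81-fold higher number from compound 1 to compound 2 (1.91 log units; beyond the scatter), a 16-fold higher number from compound 1 to compound 3 (1.22 log units; beyond the scatter) and a 4.9-fold lower number from compound 2 to compound 3 (0.69 log units; beyond the scatter). Such swaps can clearly move the number a long way, either up or down, but none of the measured groups is a pyridinyl or carries trifluoromethyl. No direction can be read from them, so no step beyond the scatter is expected, only a wide range. The expected change is a 1.6-fold lower number from compound 3 to compound 4 (0.19 log units; within the scatter). For compound 4 the estimated value is 18000 nM, with an expected range of 3500 nM to 90000 nM.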

Compound 4, half-maximal cytotoxic concentration: 6100 nM
Compound 4: middle estimate off by 3.0-fold (0.47 log units), on the high side; measured number inside the range.
By their numbers in this assay, from the lowest: compound 1; then compound 4; then compound 3; then compound 2.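

In this assay the six-membered 2-(trifluoromethyl)pyridin-4-yl ring brings a 4.6-fold lower number from compound 3 to compound 4 (0.66 log units; beyond the scatter) and a 23-fold lower number from compound 2 to compound 4 (1.35 log units; beyond the scatter) but a 3.6-fold higher number from compound 1 to compound 4 (0.55 log units; beyond the scatter) and so places compound 4 inside the span of the three five-membered or larger groups already tested, with only compound 1 lower. Nothing measured here explains this order. The compounds shown leave open whether the ring or the trifluoromethyl accounts for the step. A plain pyridin-4-yl group, or a phenyl ring carrying trifluoromethyl, would separate the two.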